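Notes on the 4-acetylmorpholin-2-yl amide in the series

The source may report more compounds than this note shows. Statements on the series, on what has been measured and on what is new or still open speak of the compounds shown alone.

Measured in an ADME assay on microsomes from liver (Mus musculus, strain CD-1) for metabolic stability, read by LC-MS, tested at 2 uM; on this read-out higher numbers stand for a longer-lived compound and lower numbers for a shorter-lived compound:
- compound 1 `CN1CCC(NC(=O)c2ccncc2Nc2cc(-c3ccc4ccn(C)c4c3)c3nccnc3c2)CC1`: > 1 h (a limit)
- compound 2 `Cn1ccc2ccc(-c3cc(Nc4cnccc4C(=O)NCC4COCCN4)cc4nccnc34)cc21`: > 1 h (a limit)

In this assay compound 2 stands at > 1 h, which is a limit and not a number. The whole measured record amounts to the limit of > 1 h in this assay, at which 2 of the 2 values shown sit. The next structure is compound 3 `CC(=O)N1CCOC(CNC(=O)c2ccncc2Nc2cc(-c3ccc4ccn(C)c4c3)c3nccnc3c2)C1`, with the change 4-acetylmorpholin-2-yl in place of morpholin-3-yl on a saturated chain carbon bound to an amide-type nitrogen. For the measured compounds named here, the one measured step, a step that the two limits leave unreadable from compound 1 to compound 2, gives no size or direction to carry over, and no step beyond the scatter is expected in this assay. The expected move, a step that the limit leaves unreadable from compound 2 to compound 3, is an estimate only. For compound 3 the expected half-life is 1.5 h, with an estimated range of 0.7 h to 4 h. A report as a limit is also expected to be likely.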

Compound 3, half-life in the Mus musculus assay: 0.217 h
Beside the measured number, compound 3's estimate is 6.9-fold (0.84 log units) above it; measured number below the stated range.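

On a saturated chain carbon bound to an amide-type nitrogen, this position can clearly move the half-life in the Mus musculus assay, where compound 3 gives 0.217 h: the change to 4-acetylmorpholin-2-yl gives an at least 4.6-fold lower number from compound 2 to compound 3 (0.66 log units; beyond the scatter), and (4-acetylmorpholin-2-yl)methyl in place of 1-methylpiperidin-4-yl gives an at least 4.6-fold lower number from compound 1 to compound 3 (0.66 log units; beyond the scatter). The earlier pair gave no readable step, and compound 3 is the only compound shown with a number rather than a limit: the limit of > 1 h in the Mus musculus assay, at which 2 of the 3 values shown sit. In a physicochemical assay for solubility, read by spectrophotometry, measured as kinetic solubility, at pH 8, tested at 500 uM (a higher number here means a more soluble compound, a lower number a less soluble compound), compound 2 gives 239 ug/mL and compound 3 gives 268 ug/mL. In the physicochemical assay the same change gives a 1.1-fold higher number from compound 2 to compound 3 (0.05 log units; within the scatter), so the shorter half-life comes with no readable change in solubility.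

The compounds shown do not separate the acetyl group from the change of ring attachment, and a morpholin-2-yl group with a free amine or a 4-methylmorpholin-2-yl group would bear on this. As far as these compounds go, the true size of both half-life steps also stays open, as each rests on a limit.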